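Ester chain length and inhibition of Scenedesmus acutus

The source may hold more compounds than are shown below. What is called first, only, known or untested is meant among the compounds shown, and "the series" means these compounds.

Compound 1 `COC(=O)c1cc(N2C(=O)C3=C(CCCC3)C2=O)ccc1Cl` carries the shortest ester of the set; in a functional assay on the whole organism for inhibition, with Scenedesmus acutus as the target (a lower number here means a stronger inhibitor, a higher number a weaker inhibitor), compound 1 gives 1780 nM. Compound 2 `CCCCOC(=O)c1cc(N2C(=O)C3=C(CCCC3)C2=O)ccc1Cl` differs from it by propyl in place of hydrogen on a saturated chain carbon bound to an oxygen next to a carbonyl group, and in this assay compound 2 gives 6310 nM, a step of a 3.5-fold higher number from compound 1 to compound 2 (0.55 log units; beyond the scatter). Compound 3 `CCCCCOC(=O)c1cc(N2C(=O)C3=C(CCCC3)C2=O)ccc1Cl` gives 4470 nM in this assay, a step of a 2.5-fold higher number from compound 1 to compound 3 (0.40 log units; beyond the scatter). Between the two longer esters the step is a 1.4-fold lower number from compound 2 to compound 3 (0.15 log units; within the scatter), so compound 2 and compound 3 cannot be ordered against each other.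

Compound 4 `CCCCCCCCOC(=O)c1cc(N2C(=O)C3=C(CCCC3)C2=O)ccc1Cl` is not yet measured. It differs from compound 3 by propyl in place of hydrogen on a saturated chain carbon, five bonds along the chain from an oxygen next to a carbonyl group. This is the same kind of change as from compound 1 to compound 2, where propyl also entered in place of hydrogen, but the place is not the same: there the carbon was bound to an oxygen next to a carbonyl group, here it lies five bonds along the chain from an oxygen next to a carbonyl group. The core on which the change is now made, compound 3, differs from compound 1 by butyl in place of hydrogen on a saturated chain carbon bound to an oxygen next to a carbonyl group.

Both earlier extensions of the ester gave higher numbers, a 3.5-fold higher number from compound 1 to compound 2 (0.55 log units; beyond the scatter) and a 2.5-fold higher number from compound 1 to compound 3 (0.40 log units; beyond the scatter), while a 1.4-fold lower number from compound 2 to compound 3 (0.15 log units; within the scatter) shows little further movement between the longer esters; the step expected here is a 1.8-fold higher number from compound 3 to compound 4 (0.25 log units; within the scatter). For compound 4 in this assay the estimate is 8000 nM, expected to fall between 3000 nM and 25000 nM.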

Compound 4, half-maximal inhibitory concentration: > 100000 nM
Compound 4 gave a limit, no number (the forecaster's own chance of this, stated with the estimate: 15%); middle value at least 12-fold (1.09 log units) away from the limit.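

In this assay compound 4 gives > 100000 nM, which is a limit of the assay and not a number. Propyl in place of hydrogen raises the number on both cores, but its size does not carry over, with an at least 22-fold higher number from compound 3 to compound 4 (1.34 log units; beyond the scatter), and the two places of the change are not the same: the same change on two cores in this assay, a 3.5-fold higher number (0.55 log units; beyond the scatter) from compound 1 to compound 2 and an at least 22-fold higher number (1.34 log units; beyond the scatter) from compound 3 to compound 4, at least 6.3-fold (0.80 log units) apart, beyond the scatter of two such steps Butyl in place of hydrogen behaves alike, with an at least 15-fold higher number from compound 2 to compound 4 (1.19 log units; beyond the scatter), and the full chain change reads an at least 56-fold higher number from compound 1 to compound 4 (1.74 log units; beyond the scatter); these steps show a much larger effect on the longer ester, but not its true size, and the four compounds do not show the cause of the difference: the same change on two cores in this assay, a 2.5-fold higher number (0.40 log units; beyond the scatter) from compound 1 to compound 3 and an at least 15-fold higher number (1.19 log units; beyond the scatter) from compound 2 to compound 4, at least 6.3-fold (0.80 log units) apart, beyond the scatter of two such steps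

The compounds shown leave open whether the number climbs gradually or abruptly as the ester lengthens beyond compound 3, a question that a hexyl or a heptyl ester would address. Also open, going by these compounds, is how an ethyl ester or a branched ester such as isopropyl would read, and whether a chain carrying a hydroxyl group or an amine would keep the values of the shorter esters.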